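The source may report more compounds than this note shows. Statements on the series, on what has been measured and on what is new or still open speak of the compounds shown alone.

The series is followed in a functional assay on HT-29 cells (Homo sapiens) for cytotoxicity, read by sulforhodamine B assay, with a stated time of 72 h; on this read-out lower numbers stand for stronger inhibition and higher numbers for weaker inhibition. Within the data shown here, compound 3 `COc1cc2ncnc(Nc3ccc(F)c(Cl)c3)c2cc1OCCCn1c([N+](=O)[O-])cnc1C` gives 11500 nM, the highest of the three numbers so far. Compound 1 `COc1cc2ncnc(Nc3ccc(F)c(Cl)c3)c2cc1OCCCCCn1ccnc1[N+](=O)[O-]` gives 5590 nM, and compound 2 `COc1cc2ncnc(Nc3cccc(Br)c3)c2cc1OCCCn1ccnc1[N+](=O)[O-]` gives 4010 nM. Among the measured compounds shown here, the one step measured within a single change, a 2.1-fold higher number from compound 1 to compound 3 (0.31 log units; beyond the scatter), concerns the group on the chain, not the aniline portion.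

Compound 4 `COc1cc2ncnc(Nc3cccc(Br)c3)c2cc1OCCCn1c([N+](=O)[O-])cnc1C` is reached from compound 3 by a change at the other end: 3-bromophenyl in place of 3-chloro-4-fluorophenyl on a nitrogen on an aromatic ring. For the measured compounds named here, no measured step bears directly on this swap. Compounds 1 and 2 carry the two aryl groups in question, but they also differ in their chain groups, so their values show only that both lie in the same broad region, with compound 2 giving the lower of the two numbers. On that basis compound 4 is expected to show a step of a 1.4-fold lower number from compound 3 to compound 4 (0.16 log units; within the scatter) from compound 3, a change not clearly beyond the scatter. The estimate for compound 4 in this assay is 8000 nM, with a range from 3500 nM to 18000 nM.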

Compound 4, half-maximal inhibitory concentration: 5410 nM
Compound 4: middle estimate off by 1.5-fold (0.17 log units), on the high side; the measured number falls inside the stated range.
By their numbers in this assay, from the lowest: compounds 2, 4 and 1 (each within the scatter of the next); then compound 3.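

In this assay, with the 2-methyl-5-nitro-1H-imidazol-1-yl group held fixed on the chain, 3-bromophenyl in place of 3-chloro-4-fluorophenyl gives a 2.1-fold lower number from compound 3 to compound 4 (0.33 log units; beyond the scatter), so the aryl group on this nitrogen alone moves the number by a modest step. With 3-bromophenyl held fixed, 2-methyl-5-nitro-1H-imidazol-1-yl in place of 2-nitro-1H-imidazol-1-yl gives a 1.3-fold higher number from compound 2 to compound 4 (0.13 log units; within the scatter), a change that stays within the scatter. No measurement is available to explain either step.

The compounds shown leave open whether the aryl step would read the same with the 2-nitro-1H-imidazol-1-yl group on the chain. They also leave open how a phenyl ring carrying a trifluoromethyl or nitrile group would read here, or a chain ending in morpholine instead of a nitroimidazole.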